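The compounds below may be only part of what the source reports. "The series", "measured", "known", "first", "only" and "open" are said of these compounds alone.

Measured compounds in an ADME assay on Vero cells (Chlorocebus sabaeus) for cytotoxicity, read by microscopy, with a stated time of 6 days; a higher number here means that more compound is tolerated, a lower number that less compound is tolerated:
compound 1 `O=C(NCc1ccccc1)c1cncc(Cl)n1` — "not determined" (no result reported)
compound 2 `CCCCCCCCNc1cnc(C(=O)NCc2ccccc2)cn1` — 20000 nM
compound 3 `CCCCNc1nccnc1C(=O)NCc1ccccc1` — > 100000 nM

Compound 1 stands without a number of its own in this assay; for compound 1 the entry reads "not determined" (no result reported). Compound 2 gives 20000 nM in this assay. Compound 3 reaches only a limit of the assay in this assay, at > 100000 nM, and this is one of the values described by the limit of > 100000 nM in this assay, at which 1 of the 3 values shown sits.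

The piece turns to compound 4, `CCCCCNc1cncc(C(=O)NCc2ccccc2)n1`, which is not yet measured. Its difference from compound 1 is pentylamino in place of chloro on an aromatic carbon. With no number for compound 1, the step from compound 1 to compound 4 cannot be given a size or a direction; what remains is the spread of the two measured values, one a number and one a limit, between which the tolerated concentration of compound 4 may be expected to fall. The account therefore closes with an estimate rather than a step: compound 4 is expected to give about 40000 nM in this assay, with a range from 15000 nM to 150000 nM, and with a fair chance that only a limit and no number will be reported.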

Compound 4, minimum cytotoxic concentration: > 100000 nM
Compound 4: a limit, no number; the forecaster's own chance of this, stated with the estimate: 40%; middle value at least 2.5-fold (0.39 log units) from the limit.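

In this assay compound 4 gives > 100000 nM, which is a limit and not a number. Going by these compounds alone, no step from compound 1 to compound 4 can be read, as compound 1 has no number of its own. The compounds shown leave open what exchanging chloro for pentylamino does to the tolerated concentration.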